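A few compounds are considered here, and "the series" means these few. Any claim that something is new, unique, unknown or untested is made for them only; others in the source may bear on it.

Measured compounds in an assay on isolated protein for binding affinity to melanin-concentrating hormone receptor 1 (Homo sapiens); a higher number here means a weaker inhibitor, a lower number a stronger inhibitor:
- compound 1 `COc1ccc(C(=O)NC2CCN(Cc3ccc4ccccc4c3)CC2)cc1OC`: 1000 nM
- compound 2 `COc1cc(OC)cc(C(=O)NC2CCN(C(C)c3ccc4ccccc4c3)CC2)c1`: 25 nM
- compound 3 `COc1cc(OC)cc(C(=O)NC2CCN(Cc3cc4ccccc4n3C)CC2)c1`: 142 nM

Compound 3 sits second highest of the three numbers. Its nearest neighbour is compound 2, whose number is lower by a gap that lies beyond the scatter; the furthest is compound 1, whose number is higher, again beyond the scatter. No pair among these three differs in only one place, so the values are read side by side and no single change is tied to any gap.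

Compound 4 `COc1cc(OC)cc(C(=O)NC2CCN(CC[C@H](O)c3ccccc3)CC2)c1` has not yet been measured. Compared with compound 3, the change is 2-hydroxy-2-phenylethyl in place of 1-methyl-1H-indol-2-yl on a saturated chain carbon bound to an amine nitrogen in a ring. The shared core and the amide linkage stay the same. Among the compounds with values here, with no measured step of this kind to lean on, the estimate rests on where compound 3 already stands. For compound 4, a step of a 2.5-fold higher number from compound 3 to compound 4 (0.39 log units; beyond the scatter) towards a higher number is expected, of modest size. Compound 4 is therefore estimated at 350 nM, with a range from 70 nM to 1800 nM.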

Compound 4, inhibition constant: 505 nM
For compound 4 the middle estimate is 1.4-fold (0.16 log units) below the measured one; the range from low to high includes it.
By their numbers in this assay, from the lowest: compound 2; then compound 3; then compounds 4 and 1 (each within the scatter of the next).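

In this assay, within the data shown here, the step for 2-hydroxy-2-phenylethyl in place of 1-methyl-1H-indol-2-yl is the only single-place comparison in the set, and it is a 3.6-fold higher number from compound 3 to compound 4 (0.55 log units; beyond the scatter) at this position on a saturated chain carbon bound to an amine nitrogen in a ring. It shows that the position tolerates a group with one aromatic ring instead of two, plus a hydrogen-bond donor and a defined stereocentre, at a modest cost. No measurement offered here accounts for the step, and this one swap changes several features together, so the step cannot be divided among them.

The compounds shown leave open whether the hydroxyl or the loss of the second ring drives the step, and what the opposite stereocentre would give. They also do not show how a plain 2-phenylethyl chain or a 2-amino-2-phenylethyl group would read at this position.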